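The compounds below may be only part of what the source reports. "The series", "measured", "known", "first", "only" and "open" are said of these compounds alone.

Three nucleotide-derived iodoacetamides have been examined in an assay on isolated protein for inhibition of hexokinase-1 (Rattus norvegicus), with a stated time of 6 h, tested at 10 mM; a lower number here means less inhibition, a higher number more inhibition at the concentration tested (going by the name of the read-out). Compound 1, `O=C(CI)NCCCCC(=O)NCCCCCCNc1ncnc2c1ncn2[C@@H]1O[C@H](COP(=O)(O)OP(=O)(O)OP(=O)(O)O)[C@@H](O)[C@H]1O`, is one of them, and in this assay compound 1 gives 0%. Compound 2, `CN(CCCCN(C)C(=O)CCCNc1ncnc2c1ncn2[C@@H]1O[C@H](COP(=O)(O)OP(=O)(O)OP(=O)(O)O)[C@@H](O)[C@H]1O)C(=O)CCCNC(=O)CI`, carries a branched linker and in this assay compound 2 gives 0%. Compound 3, `Nc1ncnc2c1nc(NCCCCCCNC(=O)CI)n2[C@@H]1O[C@H](COP(=O)(O)OP(=O)(O)OP(=O)(O)O)[C@@H](O)[C@H]1O`, bears its chain on a different position of the shared core, and in this assay compound 3 gives 0%. Compound 1 therefore stands level with compound 2 and compound 3 at the digits reported, all three within the usual scatter of one another.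

The next compound, compound 4, `O=C(CI)NCCCCCCCCNc1ncnc2c1ncn2[C@@H]1O[C@H](COP(=O)(O)OP(=O)(O)OP(=O)(O)O)[C@@H](O)[C@H]1O`, has not yet been measured. It differs from compound 1 in one place: a group of 7 heavy atoms (4 carbon, 1 nitrogen, 1 oxygen, 1 iodine; no ring) in place of a group of 12 heavy atoms (7 carbon, 2 nitrogen, 2 oxygen, 1 iodine; no ring), on a saturated chain carbon, six bonds along the chain from a nitrogen on an aromatic ring. Among the measured compounds shown here, with no step between measured compounds available, and with compound 1 sitting at 0%, the expected step in this assay from compound 1 to compound 4 is none beyond the scatter, given as no change at the digits printed from compound 1 to compound 4 (within the scatter). Compound 4 is accordingly estimated to give 0% in this assay, with a range from 0% to 10%.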

Compound 4, a percentage reported as inhibition, at one concentration (the size of the read-out at that concentration, not a potency): 35%
Estimate against measurement, compound 4: 35 percentage points below; measured number outside the range, above it.
By their numbers in this assay, from the lowest: compounds 1, 2 and 3 (each within the scatter of the next); then compound 4.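

In this assay, the saturated chain carbon six bonds along the chain from a nitrogen on an aromatic ring proved to be a place where the read-out can move, which the three level earlier compounds had not shown. Putting 2-(((iodomethyl)carbonyl)amino)ethyl there in place of the larger group of 12 heavy atoms gives a number 35 percentage points higher from compound 1 to compound 4 (beyond the scatter) at this single concentration. Both compounds carry the iodomethyl carbonyl end, so its presence alone does not fix the read-out at zero, and no measurement shown here accounts for the step.

The pair cannot separate the loss of heavy atoms from the loss of a hydrogen-bond donor, acceptor and double bond, as these changes travel together. Going by these compounds, how a longer chain, or an amine within the chain, would read at this place remains open.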